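The compounds below may be only part of what the source reports. "The series", "measured", "known", "first", "only" and "open" are said of these compounds alone.

Measured compounds in an assay on HEK293 cells for inhibition of Steryl-sulfatase (Homo sapiens), tested at 0.1 uM; on this read-out higher numbers stand for a stronger effect at the one concentration tested and lower numbers for a weaker effect:
- compound 1, `CN(CCCN1CCCCC1)c1ccc(C(=O)N2CCc3ccc(OS(N)(=O)=O)cc3C2)cc1`: 17.4%
- compound 2, `NS(=O)(=O)Oc1ccc2c(c1)CN(C(=O)c1cccc(N3CCCCC3)c1)CC2`: 1%
- compound 3, `CCN(Cc1ccc(F)cc1)c1cccc(C(=O)N2CCc3ccc(OS(N)(=O)=O)cc3C2)c1`: 10.9%

Compound 1 gives the largest of the three numbers shown in this assay. Compound 3 sits nearest to it, within the scatter, while compound 2 lies furthest from it, beyond the scatter.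

Compound 4, `CN(CCN1CCCCC1)c1ccc(C(=O)N2CCc3ccc(OS(N)(=O)=O)cc3C2)cc1`, has not yet been measured. It differs from compound 1 in one place: piperidin-1-yl in place of (piperidin-1-yl)methyl on a saturated chain carbon, two bonds along the chain from a nitrogen on an aromatic ring. Among the measured compounds shown here, the only measured step, a number 9.9 percentage points higher from compound 2 to compound 3 (within the scatter), concerns an exchange on an aromatic carbon and so does not touch the same place as this change; it is also within the scatter. For the measured compounds named here, no measured step therefore bears directly on the move from compound 1 to compound 4, and nothing in the numbers points to a shift in either direction.

Compound 4 is accordingly expected to sit close to compound 1, with a change of a number 2.4 percentage points lower from compound 1 to compound 4 (within the scatter) in this assay. The estimated inhibition for compound 4 is 15%, in the range from 4% to 26%.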

Compound 4, a percentage reported as inhibition, at one concentration (the size of the read-out at that concentration, not a potency): 0.3%
Beside the measured number, compound 4's estimate is 14.7 percentage points above it; the whole stated range lies above it.
By their numbers in this assay, from the lowest: compounds 4, 2, 3 and 1 (each within the scatter of the next, the first and the last beyond it).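

The position on the saturated chain responds to a small change: with 2-(piperidin-1-yl)ethyl in place of 3-(piperidin-1-yl)propyl on the aromatic nitrogen, this assay gives a number 17.1 percentage points lower from compound 1 to compound 4 (beyond the scatter). Among the compounds shown here, this is the first single-place step that lies beyond the scatter, whereas the earlier step concerned an aromatic carbon and stayed within it. Since both chains end in the same piperidin-1-yl ring, the difference between the two compounds lies in chain length alone, and no data bear on why this shortening lowers the number.

Going by these compounds, it remains open whether a longer chain, such as 4-(piperidin-1-yl)butyl, would raise the number further or lower it again. Also open, on these data alone, is whether the chain's end group matters, for instance if morpholine or dimethylamino stood in place of piperidin-1-yl.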